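The source may hold more compounds than are shown below. What is called first, only, known or untested is meant among the compounds shown, and "the series" means these compounds.

Of the compounds shown here, two have numbers so far in a functional assay on PC-12 cells (Rattus norvegicus) for cytotoxicity, read by MTT assay, with stated times of 3 h and 2 h, tested at 20 uM; on this read-out higher numbers stand for a stronger effect at the one concentration tested and lower numbers for a weaker effect. Compound 1 `O=C(CCCCC1CCSS1)NCc1cn(CCCOc2ccc3ccc(=O)oc3c2)nn1` gives 42.2% in this assay. Compound 2 `O=C(CCCCC1CCSS1)NCc1cn(CCCCOc2ccc3ccc(=O)oc3c2)nn1` gives 69.8%, the higher of the two numbers, with compound 1 sitting lower by a gap beyond the usual scatter. Compound 3 `O=C(CCCCC1CCSS1)NCc1cn(CCCCOc2ccc3cc(-c4ccc(Cl)cc4)c(=O)oc3c2)nn1` awaits measurement; it differs from compound 2 by 4-chlorophenyl in place of hydrogen on an aromatic carbon. Within the data shown here, no measured pair shows the effect of such a change, so the expected step of a number 1.8 percentage points lower from compound 2 to compound 3 (within the scatter) is small and within the scatter, with no clear direction. For compound 3 the estimate is 68%, in a range from 45% to 90%.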

Compound 3, a percentage reported as activity, at one concentration (the size of the read-out at that concentration, not a potency): 68.4%
Compound 3: middle estimate off by 0.4 percentage points, on the low side; the measured number falls inside the stated range.
By their numbers in this assay, from the lowest: compound 1; then compounds 3 and 2 (each within the scatter of the next).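

In this assay, 4-chlorophenyl in place of hydrogen on the aromatic carbon two atoms from the ring oxygen gives a number 1.4 percentage points lower from compound 2 to compound 3 (within the scatter). This position therefore carries the added aromatic ring with no shift in the read-out beyond the scatter, at least on the core of compound 2. Nothing available bears on why the read-out holds.

As far as these compounds go, whether an amine or a carboxylic acid at this position would leave the read-out equally unmoved remains open. So does the effect of 4-chlorophenyl on the core of compound 1.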